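One added methyl on compound 1

A few compounds are considered here, and "the series" means these few. Any claim that something is new, unique, unknown or untested is made for them only; others in the source may bear on it.

Compound 1 (`CC(C)(C)[C@H]1C(O)=C(C2=CS(=O)(=O)c3cc(NS(C)(=O)=O)ccc3N2)C(=O)N1Cc1ccc(F)cc1`) gives > 50000 nM
Compound 2 (`CC(C)(C)[C@H]1C(O)=C(C2=CS(=O)(=O)c3cc(F)ccc3N2)C(=O)N1Cc1ccc(F)cc1`) gives > 50000 nM
Compound 3 (`CC(C)(C)[C@H]1C(O)=C(C2=CS(=O)(=O)c3cc(NS(C)(=O)=O)ccc3N2)C(=O)N1Cc1ccc(F)cc1F`) gives > 50000 nM

These values come from an ADME assay on 2209-23 cells (Homo sapiens) for cytotoxicity, read by WST assay and thymidine incorporation; on this read-out lower numbers stand for higher toxicity in this test and higher numbers for lower toxicity in this test. Each is a limit and not a number, so compound 1 stands at the limit of > 50000 nM in this assay, at which 3 of the 3 values shown sit, without an exact place. Compound 4 (`CC1=C(C2=C(O)[C@H](C(C)(C)C)N(Cc3ccc(F)cc3)C2=O)Nc2ccc(NS(C)(=O)=O)cc2S1(=O)=O`) differs from compound 1 by one change (methyl in place of hydrogen on a double-bonded ring carbon), methyl in place of hydrogen on a double-bonded ring carbon. The measured steps, a step that the two limits leave unreadable from compound 1 to compound 2 and a step that the two limits leave unreadable from compound 1 to compound 3, were made on aromatic carbons and give no size to carry over. With compound 1 at the limit > 50000 nM, no step beyond the scatter is expected in this assay. The expected step is a number no higher from compound 1 to compound 4 (the limit leaves the size open). Compound 4 is expected at 50000 nM, with an estimated range of 20000 nM to 100000 nM.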

Compound 4, half-maximal cytotoxic concentration: > 50000 nM
Compound 4: a limit, no number; the forecaster's own chance of this, stated with the estimate: 85%; the middle value sits exactly at the limit.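

Compound 1 and compound 4 are both reported only as limits, not numbers, in this assay, so no step can be read for methyl in place of hydrogen: the limit of > 50000 nM in this assay, at which 4 of the 4 values shown sit.

The compounds shown leave open where their actual values lie, and whether any of these changes alters toxicity in this assay.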